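The source may report more compounds than this note shows. Statements on the series, on what has been measured and on what is new or still open speak of the compounds shown alone.

Measured compounds in a functional assay on HeLa cells (Homo sapiens) for antiproliferative activity, read by MTT assay, with a stated time of 48 h; a higher number here means a weaker inhibitor, a lower number a stronger inhibitor:
compound 1, `COc1ccc2c(/C=C/C(=O)c3cc(OC)c(OC)c([N+](=O)[O-])c3)c[nH]c2c1`, gives 850 nM
compound 2, `COc1cc(C(=O)/C=C/c2c[nH]c3ccccc23)cc([N+](=O)[O-])c1OC`, gives 1350 nM
compound 3, `COc1ccc2c(/C=C/C(=O)c3cc(OC)c(OC)c(SC)c3)cn(C)c2c1`, gives 167 nM

Compound 3 stands lowest of the three: compound 1 is nearest and compound 2 furthest, both gaps beyond the scatter. The difference between the cores of compound 1 and compound 3 is not broken down here. From compound 1 to compound 2 the change is hydrogen in place of methoxy on an aromatic carbon, and the step in this assay is a 1.6-fold higher number from compound 1 to compound 2 (0.20 log units; within the scatter). Compound 4, `COc1cc(C(=O)/C=C/c2cn(C)c3ccccc23)cc(SC)c1OC`, is not yet measured; its change from compound 3 is hydrogen in place of methoxy on an aromatic carbon, the same change at a place described in the same words, occurring twice among these compounds. For the measured compounds named here, the expected step from compound 3 to compound 4 in this assay is a 1.6-fold higher number from compound 3 to compound 4 (0.19 log units; within the scatter), set beside the earlier one, resting on the single measured pair compound 1 to compound 2 with a 1.6-fold higher number from compound 1 to compound 2 (0.20 log units; within the scatter). Compound 4 is estimated at 260 nM, within 120 nM to 560 nM.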

Compound 4, half-maximal inhibitory concentration: 105 nM
Compound 4: middle estimate off by 2.5-fold (0.39 log units), on the high side, and the stated range ends above it.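

In this assay, hydrogen in place of methoxy on an aromatic carbon gives a 1.6-fold lower number from compound 3 to compound 4 (0.20 log units; within the scatter). Set beside the earlier step, the two do not differ beyond the scatter: the same change on two cores in this assay, a 1.6-fold higher number (0.20 log units; within the scatter) from compound 1 to compound 2 and a 1.6-fold lower number (0.20 log units; within the scatter) from compound 3 to compound 4, 2.5-fold (0.40 log units) apart, within the scatter of two such steps. For the compounds shown here, on these two cores the change carries over with no step beyond the scatter, but this rests on only two pairs and does not show that the same would hold on any other core.

The compounds shown leave open whether other groups at this place, such as a hydroxyl, an amine or a longer alkoxy chain, would behave like hydrogen or methoxy. The difference between the core of compound 1 and the core of compound 3 also remains unresolved into single changes.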